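Rigidified amide replacing hydroxy-methylcarbamoyl phenyl on the amide nitrogen

A few compounds are considered here, and "the series" means these few. Any claim that something is new, unique, unknown or untested is made for them only; others in the source may bear on it.

A group with one five-membered non-aromatic ring with 1 hetero atom and one six-membered aromatic ring of carbon only in place of 3-hydroxy-4-(methylcarbamoyl)phenyl on the amide-type nitrogen

Among the measured compounds shown here, compound 1 `CNC(=O)c1ccc(N(Cc2ccc(C3CCCCC3)cn2)C(=O)[C@H]2CCN2S(=O)(=O)c2c(F)c(F)c(F)c(F)c2F)cc1O` is the only member of the series with a number: in a functional assay on MCF7 cells (Homo sapiens) for antiproliferative activity, with a stated time of 72 h (a lower number here means that less compound is needed, a higher number that more compound is needed for the effect), compound 1 gives 3800 nM. Compound 2 `CNC(=O)c1ccc(N(Cc2cnc(C3CCCCC3)cn2)C(=O)[C@H]2CCN2S(=O)(=O)c2c(F)c(F)c(F)c(F)c2F)cc1O` has no number in this assay; for compound 2 the entry reads "not determined" (no result reported). Compound 3 `O=C1NC(=O)c2cc(N(Cc3ccc(C4CCCCC4)cn3)C(=O)[C@H]3CCN3S(=O)(=O)c3c(F)c(F)c(F)c(F)c3F)ccc21` differs from compound 1 in one place: a group of 11 heavy atoms (8 carbon, 1 nitrogen, 2 oxygen; one five-membered non-aromatic ring with 1 hetero atom, one six-membered aromatic ring of carbon only) in place of a group of 11 heavy atoms (8 carbon, 1 nitrogen, 2 oxygen; one six-membered aromatic ring of carbon only), on an amide-type nitrogen. For the measured compounds named here, no pair of measured compounds shows such a step, so its size is unknown; the expectation is a step no larger than the usual scatter, perhaps slightly toward needing more compound. Compound 3 is therefore expected to give about 5000 nM, between 1500 nM and 16000 nM, an expected step of a 1.3-fold higher number from compound 1 to compound 3 (0.12 log units; within the scatter).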

Compound 3, half-maximal effective concentration: 7000 nM
Estimate against measurement, compound 3: 1.4-fold (0.15 log units) below; the range from low to high includes it.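

Among the compounds shown here, the step of a 1.8-fold higher number from compound 1 to compound 3 (0.27 log units; within the scatter) in this assay is the first reading at this position on the amide-type nitrogen. The number stays within the scatter when the single-ring 3-hydroxy-4-(methylcarbamoyl)phenyl gives way to a two-ring group with 1 hydrogen-bond donor instead of 2. No evidence on the origin of this result is available.

Steps involving compound 2 cannot be read. Open, as far as these compounds go, is whether a carboxylic acid or a primary amide in place of the methylcarbamoyl group, or an N-methyl on the new five-membered ring, would also hold the number.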